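The source may report more compounds than this note shows. Statements on the series, on what has been measured and on what is new or still open speak of the compounds shown alone.

In a functional assay on B16-F0 cells (Mus musculus) for inhibition, read by CCK-8 assay, with a stated time of 48 h (a lower number here means a stronger inhibitor, a higher number a weaker inhibitor), compound 3 `COc1ccc(-c2cc3nccc(-c4cc(OC)c(OC)c(OC)c4)n3n2)cc1` gives 1410 nM and holds the lowest of the three numbers, below compound 2 `COc1cc(-c2ccnc3cc(-c4ccc(C(C)=O)cc4)nn23)cc(OC)c1OC` at 3930 nM and compound 1 `COc1cc(-c2ccnc3cc(-c4ccccc4)nn23)cc(OC)c1OC` at 4730 nM on the shared core. Compound 4 `CCOC(=O)c1ccc(-c2cc3nccc(-c4cc(OC)c(OC)c(OC)c4)n3n2)cc1` carries ethoxycarbonyl in place of methoxy on an aromatic carbon para to a large group. Among the measured compounds shown here, the closest precedent is a 2.8-fold lower number from compound 2 to compound 3 (0.45 log units; beyond the scatter) with methoxy replacing acetyl. The step of a 3.4-fold lower number from compound 1 to compound 3 (0.53 log units; beyond the scatter) shows methoxy against hydrogen, and a 1.2-fold lower number from compound 1 to compound 2 (0.08 log units; within the scatter) shows acetyl against hydrogen. Losing the methoxy should therefore give back most of that modest gain. The expected change is a 2.3-fold higher number from compound 3 to compound 4 (0.36 log units; beyond the scatter) as a modest rise in the number. The estimate for compound 4 is 3200 nM with a range from 1300 nM to 8000 nM as its upper end.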

Compound 4, half-maximal inhibitory concentration: > 10000 nM
Compound 4: only a limit was reported; the forecaster's own chance of this, stated with the estimate: 5%; middle value at least 3.1-fold (0.49 log units) away from the limit.
By their numbers in this assay, from the lowest: compound 3; then compounds 2 and 1 (each within the scatter of the next). At a limit, above all of these: compound 4.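

Compound 4 gives only a limit, not a number: the limit of > 10000 nM in this assay, at which 1 of the 4 values shown sits. On this aromatic carbon para to a large group, ethoxycarbonyl separates from hydrogen, an at least 2.1-fold higher number from compound 1 to compound 4 (0.32 log units; beyond the scatter), whereas acetyl did not, a 1.2-fold lower number from compound 1 to compound 2 (0.08 log units; within the scatter); the change from acetyl, with ethoxy in place of methyl on the carbonyl carbon, also counts, an at least 2.5-fold higher number from compound 2 to compound 4 (0.40 log units; beyond the scatter). Against methoxy the step is wider than any earlier one, an at least 7.0-fold higher number from compound 3 to compound 4 (0.85 log units; beyond the scatter), so this position separates its groups more sharply than the first three compounds showed.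

On these data alone, the true size of these rises remains open past the limit. A carboxylic acid or an amine on this carbon would show whether the loss follows the carbonyl or the ethoxy part.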